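Working notes on the step from compound 3 to compound 4

The compounds below may be only part of what the source reports. "The series", "measured", "known", "first", "only" and "open" are said of these compounds alone.

Measured so far:
- compound 1 `CC#CCn1c(N2CCC[C@@H](N)C2)nc2c1c(=O)n(Cc1c(Cl)cccc1C(=O)OC)c(=O)n2C`: in an ADME assay on isolated protein for inhibition of Dipeptidyl peptidase 9 (Homo sapiens), with stated times of 15 min, 60 s and 20 min (a lower number here means a stronger inhibitor, a higher number a weaker inhibitor), compound 1 gives > 100000 nM, which is a limit of the assay and not a number.
- compound 2 `CC#CCn1c(N2CCC[C@@H](N)C2)nc2c1c(=O)n(Cc1cc(Cl)ccc1C(=O)O)c(=O)n2C`: in this assay compound 2 gives > 100000 nM, again a limit, not a number.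
- compound 3 `CC#CCn1c(N2CCC[C@@H](N)C2)nc2c1c(=O)n(Cc1ccc(Br)cc1C(=O)O)c(=O)n2C`: in this assay compound 3 gives > 100000 nM, also a limit, not a number.

Compound 3 therefore has no measured number in this assay; it stands at the same limit as the two other compounds, and all three sit at the limit of > 100000 nM in this assay, at which 3 of the 3 values shown sit. The steps between them, a step that the two limits leave unreadable from compound 1 to compound 2, a step that the two limits leave unreadable from compound 1 to compound 3 and a step that the two limits leave unreadable from compound 2 to compound 3, are unreadable for the same reason: both ends are limits, so neither direction nor size can be taken from them.

Compound 4 `CC#CCn1c(N2CCC[C@@H](N)C2)nc2c1c(=O)n(Cc1ccc(Cl)cc1C(=O)OC)c(=O)n2C` is the next one to be measured. Its difference from compound 3 is 4-chloro-2-(methoxycarbonyl)phenyl in place of 4-bromo-2-carboxyphenyl on a saturated chain carbon bound to an aromatic nitrogen. Compound 1 already carries a methoxycarbonyl group on the same ring and sits at the limit, so the change of the acid into its methyl ester has, within this series, not yet produced a readable number. The step that the limit leaves unreadable from compound 3 to compound 4 is thus expected to stay inside the scatter, with no readable direction. For compound 4 the estimate in this assay is 150000 nM, in the range 50000 nM to 500000 nM, and most likely the assay will again report only a limit.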

Compound 4, half-maximal inhibitory concentration: > 100000 nM
Compound 4 ended at the assay's limit; the forecaster's own chance of this, stated with the estimate: 85%; the middle value does not contradict the limit.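

In this assay compound 4 gives > 100000 nM, a limit and not a number. The steps to compound 4 from compound 1, compound 2 and compound 3 cannot be read, as both ends of each are limits: the limit of > 100000 nM in this assay, at which 4 of the 4 values shown sit.

The compounds shown leave open whether these substituted phenyl groups differ at all in this assay.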